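The source may hold more compounds than are shown below. What is called first, only, known or untested is meant among the compounds shown, and "the series" means these compounds.

Of the compounds shown here, three built on the same core have been measured in an assay on isolated protein for inhibition of coagulation factor X (Oryctolagus cuniculus), tested at 1 uM; on this read-out higher numbers stand for more inhibition at the one concentration tested (going by the name of the read-out) and lower numbers for less inhibition. Compound 1 `O=C1[C@@H](NS(=O)(=O)c2ccc(-c3ccccn3)s2)CCN1Cc1cc2[nH]cccc-2n1` gives 8%, and compound 3 `O=C1[C@@H](NS(=O)(=O)c2ccc(-c3ccccn3)s2)CCN1Cc1cc2c[nH]ccc-2n1` gives 11%. Compound 2 `O=C1[C@@H](NS(=O)(=O)c2cc3ncccc3s2)CCN1Cc1cc2c[nH]ccc-2n1` gives 61%, the highest of the three numbers; both other compounds lie beyond the scatter below it.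

Among the measured compounds shown here, the only measured step between compounds differing in one place is a number 3 percentage points higher from compound 1 to compound 3 (within the scatter), which concerns the group on the saturated chain carbon bound to the amide-type nitrogen in the ring and leaves the sulfonyl side of the molecule untouched. It therefore does not bear on the change now at hand.

Compound 4 `O=C1[C@@H](NS(=O)(=O)c2nc3cc(Cl)ccc3[nH]2)CCN1Cc1cc2c[nH]ccc-2n1` differs from compound 2 on the sulfonyl sulfur: a group of 10 heavy atoms (7 carbon, 2 nitrogen, 1 chlorine; one five-membered aromatic ring with 2 hetero atoms, one six-membered aromatic ring of carbon only) in place of a group of 9 heavy atoms (7 carbon, 1 nitrogen, 1 sulfur; one five-membered aromatic ring with 1 hetero atom, one six-membered aromatic ring with 1 hetero atom), on a sulfonyl sulfur. For the measured compounds named here, no measured pair shows how this assay responds to a change of the group on the sulfonyl sulfur, so the expectation rests only on the starting point of compound 2. Compound 4 is expected to give 40%, with a wide range from 10% to 70%. The step expected from compound 2 to compound 4 is therefore a number 21 percentage points lower from compound 2 to compound 4 (beyond the scatter), a loss beyond the scatter, though the direction is uncertain.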

Compound 4, a percentage reported as inhibition, at one concentration (the size of the read-out at that concentration, not a potency): 31%
Compound 4: middle estimate off by 9 percentage points, on the high side; measured number inside the range.
By their numbers in this assay, from the lowest: compounds 1 and 3 (each within the scatter of the next); then compound 4; then compound 2.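

In this assay, the exchange for 5-chloro-1H-benzimidazol-2-yl gives a number 30 percentage points lower from compound 2 to compound 4 (beyond the scatter), the first measured sign that this assay responds to a change of the group on the sulfonyl sulfur. The entering group does not take the number down to the level of the pyridyl-bearing group on the same sulfur: compound 4 gives 31%, whereas compound 3 gives 11%. Nothing measured here accounts for the difference between these groups.

The ring atoms and the chlorine change together in this exchange, so the compounds shown leave open how much of the step belongs to each; the same benzimidazole without chlorine, or with a bromine or methyl group in its place, would separate them. As far as these compounds go, it also remains open whether the step would be the same with the group on the saturated chain carbon of compound 1.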